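Benzyl for tert-butyl on the oxygen next to the carbonyl

The source may report more compounds than this note shows. Statements on the series, on what has been measured and on what is new or still open speak of the compounds shown alone.

Compound 3 `CC1=C(C(=O)OC(C)(C)C)C(c2ccoc2)NC(=O)N1` in an assay on membranes from HeLa cells for displacement of a labelled ligand from adenosine receptor A3 (Homo sapiens), read by scintillation counting, with a stated time of 180 min, tested at 1 uM (on this read-out lower numbers stand for less inhibition and higher numbers for more inhibition at the one concentration tested (going by the name of the read-out)), gives 2%, level with compound 1 `COC(=O)C1=C(C)NC(=O)NC1c1ccoc1` at 2% and together the lowest of the three numbers; compound 2 `CCCOC(=O)C1=C(C)NC(=O)NC1c1ccoc1` gives 11%, with a number 9 percentage points lower from compound 2 to compound 3 (within the scatter). The change to compound 4 `CC1=C(C(=O)OCc2ccccc2)C(c2ccoc2)NC(=O)N1` is benzyl in place of tert-butyl on an oxygen next to a carbonyl group. For the measured compounds named here, the measured steps that bear on it are a number 9 percentage points higher from compound 1 to compound 2 (within the scatter) and no change at the digits printed from compound 1 to compound 3 (within the scatter), both within the scatter, so enlarging the group on this oxygen has so far not moved the read-out; no step to a benzyl, or to any ring at this place, has been measured. The expected step is therefore a number 3 percentage points higher from compound 3 to compound 4 (within the scatter), none beyond the scatter. Compound 4 is estimated at 5%, ranging from -5% to 20%.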

Compound 4, a percentage reported as inhibition, at one concentration (the size of the read-out at that concentration, not a potency): 1%
Estimate against measurement, compound 4: 4 percentage points above, and the stated range covers the measured number.
By their numbers in this assay, from the lowest: compounds 4, 1, 3 and 2 (each within the scatter of the next).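

Benzyl puts the first ring on the oxygen next to a carbonyl group, and in this assay the steps of a number 1 percentage points lower from compound 3 to compound 4 (within the scatter) and a number 1 percentage points lower from compound 1 to compound 4 (within the scatter) and a number 10 percentage points lower from compound 2 to compound 4 (within the scatter) all remain small. A six-membered aromatic ring of carbon only on this oxygen therefore gives no step beyond the scatter, as with the chains in compounds 1, 2 and 3. Nothing available accounts for this flat result.

As far as these compounds go, whether a longer chain, or a benzyl carrying an amine or a carboxylic acid, would give a step beyond the scatter stays open. With every number this low, the read-out at one concentration gives no potency for any of these compounds.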